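The compounds below may be only part of what the source reports. "The series", "measured", "known", "first", "only" and "open" are said of these compounds alone.

Of the compounds shown here, three sharing one core have been measured in an assay (Cricetulus griseus) for inhibition of aldehyde dehydrogenase, mitochondrial (Homo sapiens); a higher number here means a weaker inhibitor, a lower number a stronger inhibitor. Compound 1 `CCOC(=O)CCCCCOc1ccc2c(=O)c(-c3ccc(O)cc3)coc2c1` gives 280 nM and stands second highest of the three numbers; its nearest neighbour is compound 3 `C=CCOc1ccc2c(=O)c(-c3ccc(O)cc3)coc2c1`, which gives 180 nM, and the furthest is compound 2 `O=C(O)COc1ccc2c(=O)c(-c3ccc(O)cc3)coc2c1`, which gives 1200 nM. The step of a 1.6-fold lower number from compound 1 to compound 3 (0.19 log units; within the scatter) lies within the scatter, whereas a 4.3-fold higher number from compound 1 to compound 2 (0.63 log units; beyond the scatter) and a 6.7-fold lower number from compound 2 to compound 3 (0.82 log units; beyond the scatter) both lie beyond it.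

Compound 4 `O=C(O)CCCCCCCCCCCOc1ccc2c(=O)c(-c3ccc(O)cc3)coc2c1` has not yet been measured. It differs from compound 1 by 6-carboxyhexyl in place of ethoxycarbonyl on a saturated chain carbon, five bonds along the chain from an oxygen on an aromatic ring.

Among the compounds with values here, two measured steps bear on this change. The step of a 4.3-fold higher number from compound 1 to compound 2 (0.63 log units; beyond the scatter) shows that exchanging the ester for a free carboxy group on the chain cost potency, though there the chain was also shortened. The step of a 1.6-fold lower number from compound 1 to compound 3 (0.19 log units; within the scatter) shows that a change in chain length alone, from the ester-bearing chain to vinyl, stayed within the scatter. Because the step of a 4.3-fold higher number from compound 1 to compound 2 (0.63 log units; beyond the scatter) points to a weaker inhibitor once the acid appears, a modest loss is expected for compound 4, tempered by the longer chain, giving an expected 2.0-fold higher number from compound 1 to compound 4 (0.29 log units; within the scatter). Compound 4 is therefore estimated at 550 nM, with a range from 200 nM to 1500 nM.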

Compound 4, half-maximal inhibitory concentration: 130 nM
The estimate for compound 4 lay 4.2-fold (0.63 log units) above the measured number; the measured number lies below the stated range.
By their numbers in this assay, from the lowest: compounds 4, 3 and 1 (each within the scatter of the next, the first and the last beyond it); then compound 2.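

In this assay, putting 6-carboxyhexyl in place of ethoxycarbonyl on a saturated chain carbon, five bonds along the chain from an oxygen on an aromatic ring, gave a 2.2-fold lower number from compound 1 to compound 4 (0.33 log units; beyond the scatter), so a free carboxy group at the end of the chain does not by itself go with a weaker inhibitor at this position. Among the earlier compounds, the free carboxy group appeared only on the short chain, where compound 2 gives 1200 nM, whereas at the end of the longer chain compound 4 gives 130 nM, which shows that the loss seen with compound 2 does not hold for every acid in this set. Nothing measured here gives a reason for this difference.

From the compounds shown here alone, it remains open whether the longer chain or the free carboxy group carries the step, as both change together in compound 4, and the ethyl ester of the same longer chain would separate the two. Also open, going by these compounds, is how an amine or a primary amide at the end of such a chain would read in this assay.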